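From 4-methylphenyl to thiophen-2-yl on a sulfonyl sulfur

This account rests on a few compounds, and the source may have more. Where it says the series, first, only, none or still open, it means among the compounds named here.

Of the compounds shown here, two sharing one core have been tested so far in a functional assay on A549 cells (Homo sapiens) for antiproliferative activity, read by MTT assay, with a stated time of 48 h; on this read-out higher numbers stand for weaker inhibition and lower numbers for stronger inhibition. Compound 1 `CCNc1ccc2ncc(-c3cnn(C)c3)cc2n1` gives > 50000 nM, which is a limit of the assay and not a number. For the measured compounds named here, compound 2 `Cc1ccc(S(=O)(=O)Nc2ccc3ncc(-c4cnn(C)c4)cc3n2)cc1` gives 45500 nM in this assay, the only actual number available. Compound 3 `Cn1cc(-c2cnc3ccc(NS(=O)(=O)c4cccs4)nc3c2)cn1` keeps the core of compound 2 and carries thiophen-2-yl in place of 4-methylphenyl on a sulfonyl sulfur. Going by the values given here, no measured pair of compounds tests this exchange, so the expectation stays close to compound 2 at 45500 nM. The expected change is a 1.3-fold lower number from compound 2 to compound 3 (0.11 log units; within the scatter), a small shift toward stronger inhibition that would not go beyond the scatter. For compound 3 the estimated value is 35000 nM, with an expected range from 12000 nM to 50000 nM.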

Compound 3, half-maximal inhibitory concentration: 39500 nM
Compound 3: middle estimate off by 1.1-fold (0.05 log units), on the low side, within the range that was stated.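

In this assay, the exchange on the sulfonyl sulfur gives a 1.2-fold lower number from compound 2 to compound 3 (0.06 log units; within the scatter), so the values do not separate thiophen-2-yl from 4-methylphenyl at this place, even though one ring is five-membered with a sulfur and the other is six-membered of carbon only. The change of ethyl to (thiophen-2-yl)sulfonyl on the nitrogen on an aromatic ring gives an at least 1.2-fold lower number from compound 1 to compound 3 (0.10 log units; that floor lies within the scatter), so this step has only a floor, and that floor does not go beyond the scatter. The value of compound 1 is a limit and not a number, which leaves the full size of that step unread: the limit of > 50000 nM in this assay, at which 1 of the 3 values shown sits.

The compounds shown leave open whether any group on the sulfonyl sulfur can move the number beyond the scatter. An amine or a carboxylic acid on the ring, or a longer chain in its place, would be one such test.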